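The compounds below may be only part of what the source reports. "The series", "measured", "known", "first", "only" and "open" are said of these compounds alone.

Within the data shown here, compound 2 `Nc1ccc(CNC(=O)CC2c3ccccc3N=C(N3CCCCC3)N2c2ccccc2)cc1` gives 66.8% in a functional assay on cells (Oocyte) for inhibition of Voltage-dependent T-type calcium channel subunit alpha-1H (Homo sapiens), tested at 100 uM (a lower number here means less inhibition, a higher number more inhibition at the concentration tested (going by the name of the read-out)), the lower of the two numbers known so far. Among the measured compounds shown here, compound 1 `O=C(CC1c2ccccc2N=C(N2CCCCC2)N1c1ccccc1)NCc1ccccc1` gives 77% in this assay; the step of a number 10.2 percentage points lower from compound 1 to compound 2 (beyond the scatter) is the only measured step, and it altered the same place that changes again now. Compound 3 `Cc1ccc(S(=O)(=O)Nc2ccc(CNC(=O)CC3c4ccccc4N=C(N4CCCCC4)N3c3ccccc3)cc2)cc1` differs from compound 2 by (4-methylphenyl)sulfonyl in place of hydrogen on a nitrogen on an aromatic ring. For the measured compounds named here, no measured step shows what such a large added group does here; the only guide is that a smaller change at this place moved the number modestly. The step from compound 2 to compound 3 is therefore expected to be small relative to the uncertainty, about a number 3.8 percentage points lower from compound 2 to compound 3 (within the scatter). For compound 3 the estimate in this assay is 63%, with a range from 42% to 84%.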

Compound 3, a percentage reported as inhibition, at one concentration (the size of the read-out at that concentration, not a potency): 84.7%
Estimate against measurement, compound 3: 21.7 percentage points below; the measured number lies above the stated range.
By their numbers in this assay, from the lowest: compound 2; then compounds 1 and 3 (each within the scatter of the next).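

In this assay, putting (4-methylphenyl)sulfonyl on the nitrogen of the amino group gives a number 17.9 percentage points higher from compound 2 to compound 3 (beyond the scatter), so this position accepts a group of 10 heavy atoms and the number does not fall further. The earlier step, a number 10.2 percentage points lower from compound 1 to compound 2 (beyond the scatter), showed only a drop at this place, and that drop does not carry over to the larger group: the full replacement of hydrogen by ((4-methylphenyl)sulfonyl)amino gives a number 7.7 percentage points higher from compound 1 to compound 3 (within the scatter). Nothing measured here explains this rise from the amino compound.

The compounds shown do not separate the part played by the sulfonyl from that of the 4-methylphenyl ring, a question that a methanesulfonyl or an acetyl group on the same nitrogen could address. A benzoyl group there would also test whether the sulfonyl link itself matters.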